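Pyridinyl to Chlorophenyl on the Piperidine Side Chain

A few compounds are considered here, and "the series" means these few. Any claim that something is new, unique, unknown or untested is made for them only; others in the source may bear on it.

Compounds measured so far:
- compound 1, `COC(=O)c1ccc(N2CCC(O)(Cn3cnc4c(Br)n(C)nc4c3=O)CC2)c(Cl)c1`: 157 nM
- compound 2, `O=c1c2cnn(-c3ccc(F)cc3)c2ncn1CC1(O)CCN(Cc2cccnc2)CC1`: "not determined" (no result reported)
- compound 3, `O=c1c2cnn(-c3ccc(F)cc3)c2ncn1CC1(O)CCN(Cc2ccc(F)cc2)CC1`: "not determined" (no result reported)

For the measured compounds named here, compound 1 is the only member of this set with a numerical result; in an assay on Sf21 cells for inhibition of ubiquitin carboxyl-terminal hydrolase 7 (Homo sapiens), read by spectrophotometry, with stated times of 30 min and 2 h (on this read-out lower numbers stand for stronger inhibition and higher numbers for weaker inhibition), compound 1 gives 157 nM. Compound 2 stands without a number in this assay, and compound 3 likewise carries no result, so neither offers a point of comparison for the core they share. The step of interest leads from compound 2 to compound 4, `O=c1c2cnn(-c3ccc(F)cc3)c2ncn1CC1(O)CCN(Cc2ccccc2Cl)CC1`, which awaits measurement. The change is 2-chlorophenyl in place of pyridin-3-yl on a saturated chain carbon bound to an amine nitrogen in a ring. Going by the values given here, no compound of this core has a number in this assay. On these data alone, no direction can therefore be drawn for the step, and its size beyond the scatter remains open. Compound 1, with a different core, offers only a loose anchor. Compound 4 is therefore expected to give roughly 500 nM, within a wide range from 80 nM to 4000 nM.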

Compound 4, half-maximal inhibitory concentration: 3400 nM
Compound 4: middle estimate off by 6.8-fold (0.83 log units), on the low side; the range from low to high includes it.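

In this assay compound 4 gives 3400 nM but compound 2 stands without a number, so no step can be read between them. The compounds shown leave open how 2-chlorophenyl compares with pyridin-3-yl on this core. Nothing shown bears on an explanation for the value of compound 4.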